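Hydroxy to Chloro on a Shared Core

The source may report more compounds than this note shows. Statements on the series, on what has been measured and on what is new or still open speak of the compounds shown alone.

Compound 1, `COc1ccc(C(=O)/C=C/c2cc3ccccc3[nH]c2=O)cc1`: 40200 nM
Compound 2, `O=C(/C=C/c1cc2ccccc2[nH]c1=O)c1ccc(O)cc1`: > 100000 nM

In an ADME assay on SW-620 cells (Homo sapiens) for cytotoxicity, read by sulforhodamine B assay, with a stated time of 24 h (a higher number here means that more compound is tolerated, a lower number that less compound is tolerated), compound 1 gives 40200 nM. For compound 2 this assay reports only a limit, > 100000 nM, so compound 2 stands at the limit of > 100000 nM in this assay, at which 1 of the 2 values shown sits. Within the data shown here, the single measured step is an at least 2.4-fold higher number from compound 1 to compound 2 (0.39 log units; beyond the scatter). Compound 3, `O=C(/C=C/c1cc2ccccc2[nH]c1=O)c1ccc(Cl)cc1`, differs from compound 2 by chloro in place of hydroxy on an aromatic carbon. Among the measured compounds shown here, no measured step involves a chloro, so that step guides only loosely; a number between the two measured compounds is expected, with an estimated step of an at least 2.0-fold lower number from compound 2 to compound 3 (0.30 log units; that floor lies within the scatter). Compound 3 is thus estimated at 50000 nM, within 15000 nM to 150000 nM.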

Compound 3, concentration lethal to 50% of the cells: 56600 nM
Compound 3: the middle estimate sits 1.1-fold (0.05 log units) below what was measured, and the stated range covers the measured number.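

In this assay, replacing hydroxy with chloro gives an at least 1.7-fold lower number from compound 2 to compound 3 (0.24 log units; that floor lies within the scatter), so this swap has no firm effect yet. Chloro and methoxy on this aromatic carbon cannot be told apart, with a 1.4-fold higher number from compound 1 to compound 3 (0.15 log units; within the scatter). The true size of the hydroxy-to-chloro step stays unknown, since compound 2 has only a limit: the limit of > 100000 nM in this assay, at which 1 of the 3 values shown sits.

The compounds shown leave open whether hydroxy truly stands apart from chloro and methoxy. They also leave open how an amine or a carboxylic acid would read at this place on the ring.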